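Swapping a Hydroxymethylcyclopropyl Ring for a Sulfonic Acid Chain

The compounds below may be only part of what the source reports. "The series", "measured", "known", "first", "only" and "open" are said of these compounds alone.

Compound 1 `CCCCCCCCCCCC(=O)OC[C@H](CSC[C@@H](N)C(=O)N[C@@H](C)CO)OC(=O)CCCCCCCCCCC` gives 1560 nM in an assay on HEK293 cells for agonist activity at Toll-like receptor 2 (Homo sapiens); on this read-out higher numbers stand for an effect only at larger amounts of compound and lower numbers for an effect already at smaller amounts.
Compound 2 `CCCCCCCCCCCC(=O)OC[C@H](CSC[C@@H](N)C(=O)NCCCCCCO)OC(=O)CCCCCCCCCCC` gives 33 nM in this assay.
Compound 3 `CCCCCCCCCCCC(=O)OC[C@H](CSC[C@@H](N)C(=O)NC1(CO)CC1)OC(=O)CCCCCCCCCCC` gives 265 nM in this assay.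

Among these three numbers compound 3 stands second highest. The step of a 5.9-fold lower number from compound 1 to compound 3 (0.77 log units; beyond the scatter) separates it from compound 1, and the step of an 8.0-fold higher number from compound 2 to compound 3 (0.90 log units; beyond the scatter) separates it from compound 2, so compound 3 sits clearly between the other two.

Compound 4 `CCCCCCCCCCCC(=O)OC[C@H](CSC[C@@H](N)C(=O)NCCCS(=O)(=O)O)OC(=O)CCCCCCCCCCC` differs from compound 3 in one place: 3-sulfopropyl in place of 1-(hydroxymethyl)cyclopropyl on an amide-type nitrogen. Like the 6-hydroxyhexyl of compound 2, the entering group is a chain with no ring. Going by the values given here, two measured steps bear on this. The step of a 47-fold lower number from compound 1 to compound 2 (1.67 log units; beyond the scatter) shows that moving from a branched group to a chain gave a large drop in the number, and the step of an 8.0-fold higher number from compound 2 to compound 3 (0.90 log units; beyond the scatter) shows that replacing that chain with the ring raised it again. Among the compounds with values here, no measured step tests a sulfonic acid, so the expectation rests on the chain alone and is uncertain. A modest move toward lower numbers is expected, a 3.3-fold lower number from compound 3 to compound 4 (0.52 log units; beyond the scatter). Compound 4 is therefore estimated at 80 nM, with a likely range from 15 nM to 400 nM.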

Compound 4, half-maximal effective concentration: 5560 nM
Estimate against measurement, compound 4: 70-fold (1.84 log units) below; the whole stated range lies below it.
By their numbers in this assay, from the lowest: compound 2; then compound 3; then compound 1; then compound 4.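

At this position, a chain on the amide-type nitrogen does not by itself bring a low number in this assay: the 3-sulfopropyl chain gives a 21-fold higher number from compound 3 to compound 4 (1.32 log units; beyond the scatter), the opposite direction to the earlier move from a branched group to the 6-hydroxyhexyl chain. The two chains differ in length and in what ends them, and together those differences amount to a 170-fold higher number from compound 2 to compound 4 (2.23 log units; beyond the scatter), the largest step in the set. The sulfonic acid chain also fares worse than the small branched group, with a 3.6-fold higher number from compound 1 to compound 4 (0.55 log units; beyond the scatter), so compound 4 has the highest number of the four.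

No measurement shown gives a reason for these steps.

The compounds shown do not separate chain length from end group: a 3-hydroxypropyl chain or a 6-sulfohexyl chain would pull the two apart, and a carboxylic acid or an amine at the chain end would show how other end groups compare.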